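The compounds below may be only part of what the source reports. "The series", "measured", "known", "first", "only" and "open" are said of these compounds alone.

The three measured compounds share one core that carries a silicon-bearing chain, and all were tested in a functional assay on aorta (Rattus norvegicus); on this read-out higher numbers stand for weaker inhibition and lower numbers for stronger inhibition. Compound 1 `CC(C)(C)[Si](OCCc1ccc(=O)[nH]n1)(c1ccccc1)c1ccccc1` gives 56200 nM in this assay, the lower of the two plain numbers, though compound 1 and compound 2 sit within the scatter of each other. Compound 2 `CC(C)(C)[Si](OCCCc1ccc(=O)[nH]n1)(c1ccccc1)c1ccccc1` gives 78300 nM in this assay, and the step of a 1.4-fold higher number from compound 1 to compound 2 (0.14 log units; within the scatter) is small. Compound 3 `Cn1nc(CCCO[Si](c2ccccc2)(c2ccccc2)C(C)(C)C)ccc1=O` reaches only the limit > 100000 nM in this assay, which is a limit and not a number. The step of an at least 1.2-fold higher number from compound 2 to compound 3 (0.10 log units; that floor lies within the scatter) is the one that bears on the change examined here. Compound 4 `CC(C)(C)[Si](OCCc1ccc(=O)n(Cc2ccccc2)n1)(c1ccccc1)c1ccccc1` differs from compound 1 by benzyl in place of hydrogen on an aromatic nitrogen. Because the closest measured step, methyl in place of hydrogen on an aromatic nitrogen, ended at the limit of > 100000 nM in this assay, at which 1 of the 3 values shown sits, a move toward a higher number, or again a limit, is expected for benzyl. Compound 4 is therefore estimated at about 110000 nM, in a range from 40000 nM to 300000 nM. That estimate means an expected step of a 2.0-fold higher number from compound 1 to compound 4 (0.29 log units; within the scatter).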

Compound 4, half-maximal inhibitory concentration: > 100000 nM
Compound 4: only a limit was reported (the forecaster's own chance of this, stated with the estimate: 55%); the middle value lies beyond the limit too.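

On the aromatic nitrogen of the core of compound 1, benzyl in place of hydrogen takes the read-out in this assay to a limit: compound 4 gives > 100000 nM, which is a limit and not a number. From the compounds shown here alone, the step, an at least 1.7-fold higher number from compound 1 to compound 4 (0.25 log units; that floor lies within the scatter), gives only a floor, so it does not establish a real loss of inhibition, and the true size of the change stays unknown. What is new is that a group much larger than methyl, carrying its own carbon ring, also gives no plain number, so both compounds with a group on this nitrogen, compound 3 and compound 4, now end at the limit: the limit of > 100000 nM in this assay, at which 2 of the 4 values shown sit.

Going by these compounds, how far either compound lies past that limit remains open, so methyl and benzyl cannot be ranked. Also open, on these data alone, is whether a benzyl ring bearing an amine or a carboxylic acid would bring back a plain number.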